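The source may hold more compounds than are shown below. What is called first, only, known or untested is meant among the compounds shown, and "the series" means these compounds.

Of the compounds shown here, three share one core and have been tested in a functional assay on HEL cells (Homo sapiens); a higher number here means that more compound is tolerated, a lower number that less compound is tolerated. Compound 1 `CCOC(=O)NC(=O)NC1=CS(=O)(=O)O[C@@]12[C@@H](CO[Si](C)(C)C(C)(C)C)O[C@@H](n1cc(C)c(=O)n(C)c1=O)[C@@H]2O[Si](C)(C)C(C)(C)C` gives 14000 nM. Compound 2 `CCNC(=O)NC1=CS(=O)(=O)O[C@@]12[C@@H](CO[Si](C)(C)C(C)(C)C)O[C@@H](n1cc(C)c(=O)n(C)c1=O)[C@@H]2O[Si](C)(C)C(C)(C)C` gives 10000 nM, the lowest of the three numbers, though the change a 1.4-fold lower number from compound 1 to compound 2 (0.15 log units; within the scatter) lies within the scatter, so compounds 1 and 2 read alike. Compound 3 `Cc1cn([C@@H]2O[C@H](CO[Si](C)(C)C(C)(C)C)[C@@]3(OS(=O)(=O)C=C3NCCC(=O)OCc3ccccc3)[C@H]2O[Si](C)(C)C(C)(C)C)c(=O)n(C)c1=O` gives 200000 nM, and here the change is large: a 20-fold higher number from compound 2 to compound 3 (1.30 log units; beyond the scatter), and likewise a 14-fold higher number from compound 1 to compound 3 (1.15 log units; beyond the scatter).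

Compound 4 `Cc1cn([C@@H]2O[C@H](CO[Si](C)(C)C(C)(C)C)[C@@]3(OS(=O)(=O)C=C3NC(=O)c3ccccc3)[C@H]2O[Si](C)(C)C(C)(C)C)c(=O)n(C)c1=O` is not yet measured. Its difference from compound 2 is phenyl in place of ethylamino on a carbonyl carbon; the carbonyl stays attached to the amide-type nitrogen on the core, so the group becomes benzamido rather than (ethylcarbamoyl)amino. Among the measured compounds shown here, no measured step shows this exact exchange. For the measured compounds named here, the one large step known, from compound 2 to compound 3, replaced the whole ethylcarbamoyl group, while swapping ethyl for ethoxycarbonyl in compound 1 changed little. Keeping the carbonyl but dropping the ethylamino suggests a small rise, so compound 4 is expected near 20000 nM, between 7000 nM and 60000 nM, an estimated change of a 2.0-fold higher number from compound 2 to compound 4 (0.30 log units; within the scatter).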

Compound 4, half-maximal cytotoxic concentration: 9700 nM
For compound 4 the middle estimate is 2.1-fold (0.31 log units) above the measured one; measured number inside the range.
By their numbers in this assay, from the lowest: compounds 4, 2 and 1 (each within the scatter of the next); then compound 3.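

In this assay, the exchange of ethylamino for phenyl on the carbonyl carbon leaves the reading in place: there is a 1.0-fold lower number from compound 2 to compound 4 (0.01 log units; within the scatter), and likewise a 1.4-fold lower number from compound 1 to compound 4 (0.16 log units; within the scatter), so three different groups on that carbonyl read alike. The only large difference remains with compound 3, which has no carbonyl on that nitrogen, as shown by a 21-fold lower number from compound 3 to compound 4 (1.31 log units; beyond the scatter), so among these four compounds a carbonyl at this nitrogen goes with the lower numbers. Nothing here offers an explanation for this pattern.

The compounds shown leave open whether a bare amine at this nitrogen would read like compound 3 or like the other three. They also cannot separate the loss of the carbonyl from the presence of the longer benzyl ester chain in compound 3, and an acetyl group would test how small the carbonyl substituent can be.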